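The compounds below may be only part of what the source reports. "The series", "measured", "known", "first", "only" and "open" are said of these compounds alone.

Compound 1 `CC(Sc1nc2c(cnn2C)c(=O)n1-c1ccccc1)c1ccccc1` has the lower number of the two measured compounds. In an assay on PEO1 cells for inhibition of Retinaldehyde dehydrogenase 3 (Homo sapiens), read by flow cytometry, with a stated time of 30 min, tested at 1 uM (on this read-out higher numbers stand for more inhibition at the one concentration tested (going by the name of the read-out) and lower numbers for less inhibition), compound 1 gives 47%, the lowest of the two numbers recorded. Compound 2 `CC(Sc1nc2nn(C3COC3)cc2c(=O)n1-c1ccccc1)c1cccnc1` gives 99% in this assay, a result that lies beyond the scatter above that of compound 1; compound 2 differs from compound 1 in more than one place, so the two values alone show only that the gap is real, not which change carries it.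

Compound 3 `CC(Sc1nc2c(cnn2C)c(=O)n1-c1ccccc1)c1cccc(O)c1` is the not yet measured compound. It differs from compound 1 by hydroxy in place of hydrogen on an aromatic carbon. Within the data shown here, no measured pair in this set shows that change, so there is no basis for a large step in either direction. The step from compound 1 to compound 3 is expected to be small and upward, about a number 8 percentage points higher from compound 1 to compound 3 (within the scatter). Compound 3 is therefore expected to give 55% in this assay, in the range 30% to 80%.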

Compound 3, a percentage reported as inhibition, at one concentration (the size of the read-out at that concentration, not a potency): 61%
Compound 3: middle estimate off by 6 percentage points, on the low side, within the range that was stated.
By their numbers in this assay, from the lowest: compound 1; then compound 3; then compound 2.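

Among these compounds, the change from phenyl to 3-hydroxyphenyl supplies the first step in this set that can be read at a single place: in this assay the record shows a number 14 percentage points higher from compound 1 to compound 3 (beyond the scatter). This means that a hydroxy group on this six-membered aromatic ring, meta to a large group, does not cost inhibition at the one concentration tested, which the earlier pair could not show because compound 1 and compound 2 differ in more than one place. No measurement at hand gives a reason for the step.

Going by these compounds, it remains open whether the gain is specific to hydroxy, since an amine, a methoxy group or a carboxylic acid at the same place could give a different number. On these data alone, it also remains open how far the step carries to other compounds, as it rests on a single pair.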